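The source may hold more compounds than are shown below. What is called first, only, known or untested is meant among the compounds shown, and "the series" means these compounds.

Working notes on the series in an ADME assay on PBMC cells (Homo sapiens) for cytotoxicity, read by CellTiter-Glo, with a stated time of 72 h; on this read-out higher numbers stand for weaker inhibition and lower numbers for stronger inhibition. Compound 1 (`CO[C@@H]1[C@H](N(C)c2ncc(-c3c[nH]c4ccc(Cl)cc34)s2)C[C@H]2O[C@]1(C)n1c3ccccc3c3c4c(c5c6ccccc6n2c5c31)C(=O)NC4`) gives > 10000 nM, which is a limit of the assay. Compound 2 (`CO[C@@H]1[C@H](N(C)c2ncc(-c3c[nH]c4ccccc34)s2)C[C@H]2O[C@]1(C)n1c3ccccc3c3c4c(c5c6cc(Cl)ccc6n2c5c31)C(=O)NC4`) gives > 10000 nM, also a limit and not a number. Compound 3 (`CO[C@@H]1[C@H](N(C)c2ncc(-c3c[nH]c4ccc(Cl)cc34)s2)C[C@H]2O[C@]1(C)n1c3ccccc3c3c4c(c5c6cc(Cl)ccc6n2c5c31)C(=O)NC4`) has chloro in place of hydrogen on an aromatic carbon of compound 2, taking 1H-indol-3-yl to 5-chloro-1H-indol-3-yl: chloro in place of hydrogen on an aromatic carbon. Compound 1 already carries that 5-chloro-1H-indol-3-yl group and gives > 10000 nM, a limit. No change beyond the scatter is therefore expected in this assay, and the estimated move is a number no higher from compound 2 to compound 3 (the limit leaves the size open). For compound 3 the expected value is 10000 nM, with an estimated range of 4000 nM to 20000 nM.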

Compound 3, half-maximal inhibitory concentration: > 10000 nM
Compound 3: no number, only a limit; the forecaster's own chance of this, stated with the estimate: 80%; the middle value lies on the limit itself.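

No step to compound 3 from compound 1 or compound 2 can be read, because all three compounds stand at the same limit: the limit of > 10000 nM in this assay, at which 3 of the 3 values shown sit.

The compounds shown leave open where the true values lie and whether chloro in place of hydrogen changes them at all.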